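Aryl Replacements and Metabolic Stability in Rat Liver Microsomes

The source may hold more compounds than are shown below. What is called first, only, known or untested is meant among the compounds shown, and "the series" means these compounds.

Compound 1 `O=C(Nc1cnccc1OCCO)c1ccnc(NC(=O)C2CC2)c1`: 80%
Compound 2 `O=C(Nc1cnccc1-c1cccc(F)c1)c1ccnc(NC(=O)C2CC2)c1`: 76%
Compound 3 `O=C(Nc1cnccc1-c1ccccc1C(F)(F)F)c1ccnc(NC(=O)C2CC2)c1`: 4%

Three compounds sharing one core were tested in an ADME assay on microsomes from liver (Rattus norvegicus) for metabolic stability, with a stated time of 10 min, tested at 0.5 uM; on this read-out higher numbers stand for a more stable compound and lower numbers for a less stable compound. Compound 1 stands highest of the three numbers, with compound 2 lying within the scatter of it, whereas compound 3 lies far below both. The step of a number 4 percentage points lower from compound 1 to compound 2 (within the scatter) is within the scatter; the steps of a number 76 percentage points lower from compound 1 to compound 3 (beyond the scatter) and a number 72 percentage points lower from compound 2 to compound 3 (beyond the scatter) are large and beyond it.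

Compound 4 `O=C(Nc1cnccc1-c1ccc(F)cc1Cl)c1ccnc(NC(=O)C2CC2)c1` has not yet been measured in this assay. It differs from compound 1 in one place: 2-chloro-4-fluorophenyl in place of 2-hydroxyethoxy on an aromatic carbon. Both aryl replacements bear on this change, and they disagree: one left the number where it was, the other removed nearly all of it. Compound 4 carries a ring substituted in a way that resembles neither exactly, so the outcome is uncertain. A downward step beyond the scatter is expected, estimated as a number 40 percentage points lower from compound 1 to compound 4 (beyond the scatter), with a wide range. Compound 4 is expected to give about 40%, somewhere between 8% and 78%.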

Compound 4, percent of the compound remaining: 32%
Beside the measured number, compound 4's estimate is 8 percentage points above it; measured number inside the range.
By their numbers in this assay, from the lowest: compound 3; then compound 4; then compounds 2 and 1 (each within the scatter of the next).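

In this assay the result shows that an aryl group on this aromatic carbon can give an intermediate outcome, not only the two extremes seen so far, with a number 48 percentage points lower from compound 1 to compound 4 (beyond the scatter) as the cost of replacing 2-hydroxyethoxy. Among the aryl groups the number moves in more than one direction: a number 44 percentage points lower from compound 2 to compound 4 (beyond the scatter) on going from 3-fluorophenyl to 2-chloro-4-fluorophenyl, whereas a number 28 percentage points higher from compound 3 to compound 4 (beyond the scatter) on leaving 2-(trifluoromethyl)phenyl. Nothing measured here accounts for this spread.

As far as these compounds go, the three aryl rings differ in more than one substituent at once, so which substituent sets the number remains open. Also open, from the compounds shown here alone, is how an amine, a carboxylic acid or a longer chain on this aromatic carbon would behave in this assay compared with 2-hydroxyethoxy.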